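The compounds below may be only part of what the source reports. "The series", "measured", "known", "first", "only" and "open" are said of these compounds alone.

In a functional assay on a cell-free system (Platelet, plasma, Homo sapiens) for inhibition, with stated times of 1 min and 3 min (on this read-out higher numbers stand for weaker inhibition and lower numbers for stronger inhibition), compound 1 `CC(C)Sc1nc(NC2CCCCC2)c2ncn([C@@H]3O[C@H](CO)[C@@H](O)[C@H]3O)c2n1` gives 187000 nM and compound 2 `CCCSc1nc(NCc2ccc(OC)cc2)c2ncn([C@@H]3O[C@H](CO)[C@@H](O)[C@H]3O)c2n1` gives 181000 nM and compound 3 `CCCCSc1nc(NCc2ccccc2)c2ncn([C@@H]3O[C@H](CO)[C@@H](O)[C@H]3O)c2n1` gives 202000 nM so compound 1 stands level with both, within the usual scatter. Compound 4 `CCSc1nc(NC2CCCCC2)c2ncn([C@@H]3O[C@H](CO)[C@@H](O)[C@H]3O)c2n1` changes one place of compound 1: hydrogen in place of methyl on a saturated chain carbon bound to a saturated chain carbon and a sulfur with hydrogen in place of methyl on a saturated chain carbon bound to a saturated chain carbon and a sulfur, turning isopropylsulfanyl into ethylsulfanyl. Going by the values given here, no measured pair isolates this change. Compound 2 at 181000 nM and compound 3 at 202000 nM differ from compound 1 in more than one place yet sit level with it, so no step beyond the scatter is expected in this assay for compound 4. The expected step of a 1.0-fold higher number from compound 1 to compound 4 (0.01 log units; within the scatter) stays within the scatter. The estimate for compound 4 is 190000 nM with 110000 nM to 330000 nM as its expected range.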

Compound 4, half-maximal inhibitory concentration: 104000 nM
Beside the measured number, compound 4's estimate is 1.8-fold (0.26 log units) above it, and the stated range ends above it.
By their numbers in this assay, from the lowest: compounds 4, 2, 1 and 3 (each within the scatter of the next).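

The swap of isopropylsulfanyl for ethylsulfanyl can now be read on its own, with the rest of the molecule unchanged. In this assay, going by these compounds alone, it gives a 1.8-fold lower number from compound 1 to compound 4 (0.25 log units; within the scatter), so removing this methyl from the saturated chain carbon bound to sulfur produces no step that can be told apart from repeat-measurement noise. No supporting evidence bears on this result. Still open, going by these compounds, is whether a longer chain, such as hexyl, or a chain carrying an amine in place of ethyl on the sulfur would give a step beyond the scatter.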